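This account rests on a few compounds, and the source may have more. Where it says the series, first, only, none or still open, it means among the compounds named here.

The study concerns a shared core carried by compound 1 `COc1ccc(-c2cc(=O)c3c(OC)cc(OC)cc3[nH]2)cc1`, on which an aromatic nitrogen is left bare. In a functional assay on HepG2 cells (Homo sapiens) for antiproliferative activity, with a stated time of 72 h (a lower number here means that less compound is needed, a higher number that more compound is needed for the effect), compound 1 reaches only the limit of > 31100 nM. Compound 2 `C=CCNC(=O)n1c(-c2ccc(OC)cc2)cc(=O)c2c(OC)cc(OC)cc21` puts an allylcarbamoyl on that nitrogen. In this assay compound 2 likewise stops at the limit of > 20000 nM. Compound 3 `COc1ccc(-c2cc(=O)c3c(OC)cc(OC)cc3n2S(=O)(=O)c2ccc(C#N)cc2)cc1` carries instead a (4-cyanophenyl)sulfonyl on the aromatic nitrogen. In this assay compound 3 also gives only the limit of > 17200 nM. Compound 3 therefore stands where all three measured compounds stand, at a limit, and the two other values are limits too (the limit of > 17200 nM in this assay, at which 1 of the 3 values shown sits, (the limit of > 20000 nM in this assay, at which 1 of the 3 values shown sits), (the limit of > 31100 nM in this assay, at which 1 of the 3 values shown sits)). The steps a step that the two limits leave unreadable from compound 1 to compound 3 and a step that the two limits leave unreadable from compound 2 to compound 3 are thus unreadable, and a step that the two limits leave unreadable from compound 1 to compound 2 is unreadable as well. Compound 4 `COc1ccc(-c2cc(=O)c3c(OC)cc(OC)cc3n2S(=O)(=O)c2cc(Cl)cc(Cl)c2O)cc1` differs from compound 3 by 3,5-dichloro-2-hydroxyphenyl in place of 4-cyanophenyl on a sulfonyl sulfur. Among the measured compounds shown here, no measured step exchanges one aryl group for another on the sulfonyl sulfur, so nothing among the measured compounds gives a direction or a size for this change. The step that the limit leaves unreadable from compound 3 to compound 4 is accordingly expected to be small, and most likely not readable. Compound 4 is therefore estimated at 20000 nM in this assay, within a range from 5000 nM to 40000 nM, and is expected to be reported again as a limit.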

Compound 4, half-maximal effective concentration: > 37900 nM
Compound 4 gave a limit, no number (the forecaster's own chance of this, stated with the estimate: 75%); middle value at least 1.8-fold (0.27 log units) away from the limit.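

In this assay compound 4 gives > 37900 nM as a limit, not a number. Compound 3 also stands at a limit, so the step between compound 3 and compound 4 cannot be read. The compounds shown leave open whether in this assay any group on the aromatic nitrogen of the shared core, or any aryl group on the sulfonyl sulfur, changes the effect at all.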